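Fluoro for Chloro: an Untested Step in Cell Growth

The compounds below may be only part of what the source reports. "The series", "measured", "known", "first", "only" and "open" are said of these compounds alone.

Three compounds have been measured in a functional assay on SW-620 cells (Homo sapiens) for inhibition, read by sulforhodamine B assay, with a stated time of 48 h; a lower number here means a stronger inhibitor of growth, a higher number a weaker inhibitor of growth:

Compound 1, `N=C(N)c1ccc(-c2ccc(-c3ccc(Cl)cc3)o2)o1`, gives 1700 nM
Compound 2, `N=C(N)c1ccc(-c2ccc(-c3cncc4ccccc34)s2)s1`, gives 1080 nM
Compound 3, `N=C(N)c1ccc(-c2ccc(-c3ccc4ccccc4c3)s2)s1`, gives 1910 nM

Compound 1 holds the second highest of the three numbers. Its nearest neighbour is compound 3, whose number is slightly higher but within the usual scatter of this assay, so the two cannot be told apart. Compound 2 lies furthest away with a lower number, yet that gap also stays within the scatter, so no ordering among the three is secure. Among the measured compounds shown here, no pair of measured compounds differs in one place only, so no single structural step has a known size here.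

Compound 4, `N=C(N)c1ccc(-c2ccc(-c3ccc(F)cc3)o2)o1`, is the next compound to be measured. It departs from compound 1 by one change: fluoro in place of chloro on an aromatic carbon.

For the measured compounds named here, the measured set gives no step of this kind. The expected step from compound 1 to compound 4 is estimated as a 1.3-fold higher number from compound 1 to compound 4 (0.11 log units; within the scatter), a small shift toward a higher number that is not expected to exceed the scatter. Compound 4 is therefore expected to give about 2200 nM, with a likely range from 1000 nM to 5000 nM.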

Compound 4, concentration for 50% growth inhibition: 940 nM
Compound 4: middle estimate off by 2.3-fold (0.37 log units), on the high side; the whole stated range lies above it.
By their numbers in this assay, from the lowest: compounds 4, 2, 1 and 3 (each within the scatter of the next, the first and the last beyond it).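

Among the compounds shown here, the step from chloro to fluoro on an aromatic carbon, para to a large group, is the first single-place comparison in this set, and in this assay it comes out as a 1.8-fold lower number from compound 1 to compound 4 (0.26 log units; within the scatter). Compound 1 and compound 4 therefore cannot be told apart in this growth read-out, and at this position the exchange of one single-atom group for the other has no effect that can be separated from repeat scatter. Nothing at hand, such as a measurement on the compounds themselves or a related result, offers an explanation for the size of this step.

The compounds shown leave open whether a different group at this same position, such as an amine, a methoxy group or a carboxylic acid, would give a step beyond the scatter, as chloro and fluoro alone do not settle how much this position can vary. They also leave open whether fluoro in place of chloro would give a step of similar size on the core shared by compound 2 and compound 3.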